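Ring swap on the shared core: expectation for compound 4

This account rests on a few compounds, and the source may have more. Where it says the series, first, only, none or still open, it means among the compounds named here.

Measured so far in an in vitro functional assay on HEK285-7 cells for antagonist activity at prostaglandin D2 receptor 2 (Homo sapiens), read by BRET and beta-arrestin recruitment; a higher number here means a larger maximal response, a lower number a smaller maximal response:
compound 1 `N#Cc1cc(-c2nc(C(c3ccc(F)cc3)c3ccc(F)cc3)sc2CC(=O)O)ccc1F`, 80%
compound 2 `CCC(c1ccccc1)c1nc(-c2ccc(Cl)cc2)c(CC(=O)O)s1`, 50%
compound 3 `O=C(O)Cc1sc(C(c2ccc(F)cc2)c2ccc(F)cc2)nc1-c1cc(F)cc(F)c1`, 80%

Compound 3 stands level with compound 1 in this assay, and the two together are the highest of the three numbers; compound 2 is the furthest away, a number that is lower than compound 3 and beyond the scatter. Within the data shown here, only one pair differs in a single place: no change at the digits printed from compound 1 to compound 3 (within the scatter), a swap of the aromatic group on the five-membered core that left the maximal response where it was.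

Compound 4 `O=C(O)Cc1sc(C(c2ccc(F)cc2)c2ccc(F)cc2)nc1-c1ccnc(F)c1` is the next member and is not yet measured. It differs from compound 3 as follows: 2-fluoropyridin-4-yl in place of 3,5-difluorophenyl on an aromatic carbon. Among the measured compounds shown here, this is the same kind of change as the one between compound 1 and compound 3, a different six-membered aromatic group attached at the same position of the core, with the carboxymethyl group and the large group unchanged.

For the measured compounds named here, the one step that bears on it showed no change within the scatter, so no step beyond the scatter is expected in this assay for compound 4 either. Compound 4 is therefore expected to give 76%, with a plausible range from 60% to 90%. The step from compound 3 that this estimate implies, a number 4 percentage points lower from compound 3 to compound 4 (within the scatter), is expected to stay within the scatter.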

Compound 4, largest response reached (reported as efficacy), in percent of the reference or control that the assay uses: 80%
For compound 4 the middle estimate is 4 percentage points below the measured one; the range from low to high includes it.
By their numbers in this assay, from the lowest: compound 2; then compounds 1, 3 and 4 (each within the scatter of the next).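

In this assay, 2-fluoropyridin-4-yl in place of 3,5-difluorophenyl on this aromatic carbon gives no change at the digits printed from compound 3 to compound 4 (within the scatter) and so adds a six-membered aromatic ring with 1 hetero atom and 1 hydrogen-bond acceptor to the carbon-only rings seen here before. The comparison with the group carrying the nitrile reads the same, with no change at the digits printed from compound 1 to compound 4 (within the scatter) for 2-fluoropyridin-4-yl in place of 3-cyano-4-fluorophenyl, so all three six-membered aromatic groups at this position, on the aromatic carbon next to the ring nitrogen, lie within the scatter of one another. No measurement is at hand that would explain why the ring nitrogen and the different fluorine and nitrile patterns leave the maximal response unmoved.

Open, on these data alone, is whether this position tolerates only six-membered aromatic groups, or whether a piperidine ring, an amine or a longer alkyl chain on the same carbon would also stay within the scatter in this assay. Also open, as far as these compounds go, is how much of the maximal response depends on the carboxymethyl group and the large group, which stay the same in compound 1, compound 3 and compound 4.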